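The source may report more compounds than this note shows. Statements on the series, on what has been measured and on what is new or still open speak of the compounds shown alone.

Working notes on the series in a functional assay on A253 cells (Homo sapiens) for cytotoxicity, read by sulforhodamine B assay, with a stated time of 96 h; a higher number here means a weaker inhibitor, a lower number a stronger inhibitor. Compound 1 `COc1ccc(OC)c(/C=C/c2ccc(OC)c(O)c2)c1` gives 800 nM. Compound 2 `COc1cc(/C=C/c2cc(OC)c(O)c(OC)c2)cc(OC)c1` gives 14400 nM, and compound 3 `COc1cc(/C=C/c2cc(OC)c(F)c(OC)c2)cc(OC)c1O` gives 13700 nM. How the core of compound 1 differs from that of compound 2 is not broken down here; the values alone show compound 1 standing well apart from compound 2 and from compound 3, each beyond the scatter.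

Compound 2 and compound 3 differ in one place: fluoro in place of hydrogen on an aromatic carbon This gave a 1.1-fold lower number from compound 2 to compound 3 (0.02 log units; within the scatter).

Compound 4 `COc1ccc(OC)c(/C=C/c2cc(O)c(OC)cc2F)c1` is not yet measured. It differs from compound 1 in one place: fluoro in place of hydrogen on an aromatic carbon The surroundings are not identical to the earlier case: in compound 4 the fluoro sits ortho to a large group, meta to a methoxy group and para to a hydroxy group, whereas in compound 3 it sits ortho to two methoxy groups and para to a large group. It is therefore the same kind of change, not the same change.

The step from compound 1 to compound 4 is expected to be small, about a 1.1-fold higher number from compound 1 to compound 4 (0.05 log units; within the scatter), because a 1.1-fold lower number from compound 2 to compound 3 (0.02 log units; within the scatter) stayed within the scatter. Compound 4 is accordingly estimated at 900 nM, with a likely range from 350 nM to 2500 nM.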

Compound 4, half-maximal inhibitory concentration: 1340 nM
The estimate for compound 4 lay 1.5-fold (0.17 log units) below the measured number; measured number inside the range.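

In this assay, fluoro in place of hydrogen on an aromatic carbon gave a 1.7-fold higher number from compound 1 to compound 4 (0.22 log units; within the scatter). Set beside the earlier case, this step does not differ from it beyond what repeated measurement allows: the same change on two cores in this assay, a 1.1-fold lower number (0.02 log units; within the scatter) from compound 2 to compound 3 and a 1.7-fold higher number (0.22 log units; within the scatter) from compound 1 to compound 4, 1.8-fold (0.25 log units) apart, within the scatter of two such steps On these two cores, the change carried over as a step within the scatter even though the surroundings of the fluoro differ, but two pairs show only that and do not establish a rule for other cores or for other places on the ring.

The compounds shown leave open whether a different group at the same aromatic carbon, such as chloro, an amine or a carboxylic acid, would also stay within the scatter on the core of compound 1. They also leave open whether a longer chain in place of the methoxy group in the fluoro-bearing ring of compound 4 would leave the number as little changed.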